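The source may report more compounds than this note shows. Statements on the series, on what has been measured and on what is new or still open speak of the compounds shown alone.

Compound 1 `C/C(=N\NC(N)=O)c1ccc2[nH]c(-c3ccc(Cl)cc3)nc2c1` and compound 2 `C/C(=N\NC(N)=O)c1ccc2[nH]c(-c3ccc(C(F)(F)F)cc3)nc2c1` share one core, while compound 3 `C/C(=N\NC(N)=S)c1ccc2c(c1)nc(-c1ccc(Cl)cc1)n2C1CCCCC1` and compound 4 `C/C(=N\NC(N)=S)c1ccc2c(c1)nc(-c1ccc(C(F)(F)F)cc1)n2C1CCCCC1` share another; the difference between the two cores is not broken down here. In an ADME assay on Vero cells (Chlorocebus sabaeus) for cytotoxicity, read by MTT assay, with a stated time of 96 h (a lower number here means that less compound is tolerated, a higher number that more compound is tolerated), compound 1 gives > 100000 nM, which is a limit of the assay rather than a number. In this assay compound 2 gives > 100000 nM, again a limit. The change between them, (trifluoromethyl in place of chloro on an aromatic carbon), therefore made a step that the two limits leave unreadable from compound 1 to compound 2. In this assay compound 3 gives > 100000 nM, also a limit. The same change, (trifluoromethyl in place of chloro on an aromatic carbon), now leads to compound 4. Since (the limit of > 100000 nM in this assay, at which 3 of the 3 values shown sit), compound 4 is expected to show a number no higher from compound 3 to compound 4 (the limit leaves the size open) in this assay. Compound 4 is estimated at 100000 nM in this assay, most likely as a limit again.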

Compound 4, half-maximal cytotoxic concentration: > 100000 nM
Compound 4 ended at the assay's limit (the forecaster's own chance of this, stated with the estimate: 85%); the middle value lies on the limit itself.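

In this assay, among the compounds shown here, compound 3 and compound 4 both sit at a limit rather than a number, so no step between them can be read: the limit of > 100000 nM in this assay, at which 4 of the 4 values shown sit.

The compounds shown leave open at what concentration any of them would harm the cells, and whether trifluoromethyl in place of chloro alters that.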